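Methylating the ring amine of compound 3

The source may report more compounds than this note shows. Statements on the series, on what has been measured and on what is new or still open speak of the compounds shown alone.

Of the compounds shown here, three of a shared core have been measured in an assay on isolated protein for binding affinity to B1 bradykinin receptor (Homo sapiens); a lower number here means a stronger inhibitor, a higher number a weaker inhibitor. Compound 1 `Cc1cc(C)c2cccc(OCc3c(Cl)ccc(S(=O)(=O)NC4(C(=O)N5CCN(C(=O)CCCCC[N+](C)(C)C)CC5)CCCC4)c3Cl)c2n1` carries a long quaternary ammonium chain on its piperazine amide. In this assay compound 1 gives < 10000 nM, which is a limit of the assay rather than a number. Compound 2 `Cc1cc(C)c2cccc(OCc3c(Cl)ccc(S(=O)(=O)NC4(C(=O)N5CCN(C(=O)CCC[N+](C)(C)C)CC5)CCCC4)c3Cl)c2n1` has a shorter chain of the same kind. In this assay compound 2 gives < 10000 nM, again only a limit. The change from compound 1 to compound 2 is therefore a step that the two limits leave unreadable from compound 1 to compound 2. Compound 3 `Cc1cc(C)c2cccc(OCc3c(Cl)ccc(S(=O)(=O)NC4(C(=O)N5CCN(C(=O)[C@@H](N)CCC[N+](C)(C)C)CC5)CCNCC4)c3Cl)c2n1` replaces the cyclopentane ring with a ring holding a secondary amine and adds an amino group on the chain. In this assay compound 3 gives < 10000 nM, once more a limit. Thus compound 3 stands at the limit of < 10000 nM in this assay, at which 3 of the 3 values shown sit, and nothing within the measured set separates any compound from any other.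

Compound 4 `Cc1cc(C)c2cccc(OCc3c(Cl)ccc(S(=O)(=O)NC4(C(=O)N5CCN(C(=O)[C@@H](N)CCC[N+](C)(C)C)CC5)CCN(C)CC4)c3Cl)c2n1` differs from compound 3 by methyl in place of hydrogen on an amine nitrogen in a ring. Among the compounds with values here, no measured step touches this position, so the only guidance is that every value so far sits at the limit. The step from compound 3 to compound 4 is therefore expected to be a step that the limit leaves unreadable from compound 3 to compound 4, a change no larger than the scatter. Compound 4 is estimated in this assay at 2000 nM, within a range from 200 nM to 10000 nM.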

Compound 4, inhibition constant: < 10000 nM
Compound 4: a limit, no number (the forecaster's own chance of this, stated with the estimate: 80%); the middle value lies beyond the limit too.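

In this assay compound 4 gives < 10000 nM, a limit of the assay and not a number. Compound 3 also gives only a limit, so the step from compound 3 to compound 4 cannot be read. The compounds shown leave open how strongly any of them binds, and whether methyl in place of hydrogen on an amine nitrogen in a ring changes that at all.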